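Larger group on the aromatic nitrogen of compound 3

The compounds below may be only part of what the source reports. "The series", "measured", "known", "first", "only" and "open" are said of these compounds alone.

In a functional assay on HT-29 cells (Homo sapiens) for inhibition, read by luminescence and CellTiter-Glo, with a stated time of 24 h (on this read-out higher numbers stand for an effect only at larger amounts of compound and lower numbers for an effect already at smaller amounts), compound 1 `CN1C(=S)[C@@H](NC(=O)c2nc(Cc3ccccc3)n(CCCO)n2)COc2ccccc21` gives 209 nM, compound 2 `CN1C(=S)[C@@H](NC(=O)c2nc(Cc3ccccc3)n(CCCC(F)(F)F)n2)COc2ccccc21` gives 2380 nM and compound 3 `CN1C(=S)[C@@H](NC(=O)c2nc(Cc3ccccc3)n(CC3CCOC3)n2)COc2ccccc21` gives 4420 nM, the highest of the three numbers. Compound 4 `CN1C(=S)[C@@H](NC(=O)c2nc(Cc3ccccc3)n(C3CCN(C(=O)OC(C)(C)C)C3)n2)COc2ccccc21` differs from compound 3 on an aromatic nitrogen: a group of 12 heavy atoms (9 carbon, 1 nitrogen, 2 oxygen; one five-membered non-aromatic ring with 1 hetero atom) in place of a group of 6 heavy atoms (5 carbon, 1 oxygen; one five-membered non-aromatic ring with 1 hetero atom), on an aromatic nitrogen. For the measured compounds named here, two large steps, an 11-fold higher number from compound 1 to compound 2 (1.06 log units; beyond the scatter) and a 21-fold higher number from compound 1 to compound 3 (1.33 log units; beyond the scatter), both lead away from compound 1, the only measured compound with a hydroxy group. Compound 4 has none, and a 1.9-fold higher number from compound 2 to compound 3 (0.27 log units; within the scatter) shows two groups without hydroxy staying within the scatter. Going by the values given here, no measured step covers a group this large, so the range stays wide. In this assay the expected change is a 1.3-fold lower number from compound 3 to compound 4 (0.10 log units; within the scatter), with no step beyond the scatter anticipated. The estimate for compound 4 is 3500 nM, with an expected range from 900 nM to 13000 nM.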

Compound 4, half-maximal effective concentration: > 10000 nM
Compound 4: only a limit was reported; the forecaster's own chance of this, stated with the estimate: 15%; at least 2.8-fold (0.45 log units) between middle value and limit.
By their numbers in this assay, from the lowest: compound 1; then compounds 2 and 3 (each within the scatter of the next). At a limit, above all of these: compound 4.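

Compound 4 gives only a limit, not a number: the limit of > 10000 nM in this assay, at which 1 of the 4 values shown sits.

In this assay, the group of 12 heavy atoms on the aromatic nitrogen still separates from all three earlier groups, with an at least 2.2-fold higher number from compound 3 to compound 4 (0.35 log units; beyond the scatter), an at least 4.2-fold higher number from compound 2 to compound 4 (0.62 log units; beyond the scatter) and an at least 47-fold higher number from compound 1 to compound 4 (1.67 log units; beyond the scatter). Among the groups without hydroxy, this position therefore no longer stays within the scatter, as it did for compound 2 and compound 3.

From the compounds shown here alone, whether a free amine on the five-membered ring would stay near compound 4 remains open. So does whether a longer chain ending in hydroxy would keep the value of compound 1.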